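Ethyl in place of methylsulfanyl on a weak modulator

The compounds below may be only part of what the source reports. "The series", "measured", "known", "first", "only" and "open" are said of these compounds alone.

Measured so far:
compound 1 `CCc1ncc(C#Cc2cccc(C)c2)cn1` gives "not active" (no number reported)
compound 2 `CSc1ncc(C#Cc2ccccc2)cn1` gives 120000 nM

Of the compounds shown here, two have been tested in an assay on HEK293 cells for positive allosteric modulation of metabotropic glutamate receptor 5 (Rattus norvegicus); on this read-out lower numbers stand for an effect already at smaller amounts and higher numbers for an effect only at larger amounts of compound. Compound 1 is reported as "not active" (no number reported), so no number stands for it. Going by the values given here, compound 2 gives 120000 nM, which makes it the only compound with a number at all and places it at the very weak end of what this assay reports. Among the compounds with values here, no pair of measured compounds differs in a single place, so no step between measured values can be read.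

Compound 3 `CCc1ncc(C#Cc2ccccc2)cn1` has not yet been measured. It differs from compound 2 in one place: ethyl in place of methylsulfanyl on an aromatic carbon. The closest point of comparison is compound 1, which also carries ethyl at that place and is "not active" (no number reported) in this assay. With compound 2 already so weak, a step beyond the scatter in either direction is hard to call; the more likely outcome is a number at least as high, or no number at all.

Compound 3 is expected to give 250000 nM, with a range of 80000 nM to 800000 nM, which means an estimated 2.1-fold higher number from compound 2 to compound 3 (0.32 log units; beyond the scatter).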

Compound 3, half-maximal effective concentration: "not active" (no number reported)
Compound 3: no number reported; no gap can be computed for the estimate.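

In this assay, going by these compounds alone, compound 3 gives "not active" (no number reported), so no step from compound 2 to compound 3 can be read. Nothing measured here offers an explanation for this result. The compounds shown leave open how large any difference between ethyl and methylsulfanyl at this place on the shared core really is.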